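Aryl swap on the saturated ring carbon of compound 2

The source may report more compounds than this note shows. Statements on the series, on what has been measured and on what is new or still open speak of the compounds shown alone.

Of the compounds shown here, two carry a number so far. In a functional assay on PC-3 cells (Homo sapiens) for antiproliferative activity, read by MTT assay, tested at 5 uM (on this read-out higher numbers stand for a stronger effect at the one concentration tested and lower numbers for a weaker effect), compound 1 `COc1ccc(OC)c(C2OC(c3cc(OC)c(OC)c(OC)c3)=NN2C(C)=O)c1` gives 43.2%, and compound 2 `COc1cc(C2=NN(C(C)=O)C(c3ccc(Cl)c(Cl)c3)O2)cc(OC)c1OC` gives 26.1%. Among the compounds with values here, compound 2 stands lowest of the two; its nearest neighbour is compound 1, and the only measured step, a number 17.1 percentage points lower from compound 1 to compound 2 (beyond the scatter), separates them beyond the scatter.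

Compound 3 `COc1cc(C2=NN(C(C)=O)C(c3ccc(C(F)(F)F)cc3)O2)cc(OC)c1OC` differs from compound 2 by 4-(trifluoromethyl)phenyl in place of 3,4-dichlorophenyl on a saturated ring carbon. The step from compound 1 to compound 2 is the only one that bears on it, since it changed the same saturated ring carbon, and it was modest. It does not tell which way a trifluoromethyl-bearing aryl will move the read-out, so no step beyond the scatter is expected, a number 1.9 percentage points higher from compound 2 to compound 3 (within the scatter) being the assumed size. Compound 3 is therefore estimated at 28%, within a range of 12% to 46%, pending the measurement.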

Compound 3, a percentage reported as inhibition, at one concentration (the size of the read-out at that concentration, not a potency): -0.7%
For compound 3 the middle estimate is 28.7 percentage points above the measured one; measured number outside the range, below it.
By their numbers in this assay, from the lowest: compound 3; then compound 2; then compound 1.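

In this assay, 4-(trifluoromethyl)phenyl in place of 3,4-dichlorophenyl on the saturated ring carbon gives a number 26.8 percentage points lower from compound 2 to compound 3 (beyond the scatter), so these two aryl groups are not interchangeable at this position. Measured against 2,5-dimethoxyphenyl, the same group gives a number 43.9 percentage points lower from compound 1 to compound 3 (beyond the scatter), the largest step seen here, and the three aryl groups spread widely over the read-out. No measurement at hand explains this order of the three groups.

Whether the fall follows the trifluoromethyl group itself or the loss of the chlorine atoms stays open, since the shown aryl groups differ in both the substituent and its placing. Also open, from the compounds shown here alone, is how the read-out responds to an aryl group carrying an amine or a carboxylic acid, or to a longer alkyl chain, on this carbon.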